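Taking the chloro group off compound 2

A few compounds are considered here, and "the series" means these few. Any claim that something is new, unique, unknown or untested is made for them only; others in the source may bear on it.

Measured in a functional assay on the whole organism with Mus musculus as the target; on this read-out higher numbers stand for an effect only at larger amounts of compound and lower numbers for an effect already at smaller amounts:
compound 1 `COc1cc2c(cc1OC)C(c1ccc(N)cc1)=NN=C(S)C2`: 3.3 umol/kg
compound 2 `COc1cc2c(cc1OC)C(c1ccc(Cl)cc1)=NN=C(S)C2`: 55 umol/kg

Within the data shown here, of the two numbers so far, compound 2 has the higher one, 55 umol/kg, so it needs the larger dose for its effect. Compound 3 `COc1cc2c(cc1OC)C(c1ccccc1)=NN=C(S)C2` has not yet been measured and keeps the shared core with one change: hydrogen in place of chloro on an aromatic carbon. In words, this is hydrogen in place of chloro on an aromatic carbon. Among the measured compounds shown here, only one measured step involves this same carbon: chloro in place of amino gave a 17-fold higher number from compound 1 to compound 2 (1.22 log units; beyond the scatter), a large step beyond the scatter. Hydrogen has not yet been measured there, so that step cannot fix where it falls. A moderate move to a lower number in this assay is expected, smaller than that step and perhaps not beyond the scatter. This expected step is a 1.7-fold lower number from compound 2 to compound 3 (0.24 log units; within the scatter). For compound 3 the estimated value is 32 umol/kg, with an expected range from 11 umol/kg to 95 umol/kg.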

Compound 3, dose for half-maximal effect: 15 umol/kg
Compound 3: middle estimate off by 2.1-fold (0.33 log units), on the high side, and the stated range covers the measured number.
By their numbers in this assay, from the lowest: compound 1; then compound 3; then compound 2.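

In this assay, the unsubstituted aromatic carbon now gives a reference point: hydrogen in place of chloro gives a 3.7-fold lower number from compound 2 to compound 3 (0.56 log units; beyond the scatter), and hydrogen in place of amino gives a 4.5-fold higher number from compound 1 to compound 3 (0.66 log units; beyond the scatter). The large gap between the amino and chloro compounds therefore splits into two modest parts, each beyond the usual scatter: compared with hydrogen at this position, amino goes with a lower dose and chloro with a higher one. Nothing available here explains why the two groups move the dose in opposite directions.

Three groups at one position cannot show whether this order extends to others, such as a fluoro, a hydroxyl or a dimethylamino group. From the compounds shown here alone, it also remains open whether an amino group would give a similarly low dose elsewhere on this aromatic ring.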